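This account rests on a few compounds, and the source may have more. Where it says the series, first, only, none or still open, it means among the compounds named here.

Measured so far:
Compound 1 `Cc1ccc(-c2ccccc2OC(C)C2=NCCN2)cc1` sits at a limit in a functional assay on CHO cells for agonist activity at Alpha-2B adrenergic receptor (Homo sapiens) (a lower number here means a smaller maximal response, a higher number a larger maximal response), < 0.3.
Compound 2 `CC(Oc1ccccc1-c1ccccc1[N+](=O)[O-])C1=NCCN1` sits at a limit in this assay, < 0.3.
Compound 3 `Cc1ccccc1-c1ccccc1OC(C)C1=NCCN1` sits at a limit in this assay, < 0.3.

Compound 1 has no number of its own in this assay, only the limit shared by the whole set: the limit of < 0.3 in this assay, at which 3 of the 3 values shown sit. Compound 4 `CC(Oc1ccccc1-c1cccs1)C1=NCCN1` differs from compound 1 in one place: thiophen-2-yl in place of 4-methylphenyl on an aromatic carbon. Within the data shown here, two measured steps bear on a change at this place, a step that the two limits leave unreadable from compound 1 to compound 3 and a step that the two limits leave unreadable from compound 2 to compound 3, and neither has a readable size, since both ends sit at the limit. Nothing in the set therefore points to a step beyond the scatter in either direction, and compound 4 is expected to sit at the same limit. The estimate for compound 4 in this assay is 0.2, within 0.05 to 0.35, which means an expected step that the limit leaves unreadable from compound 1 to compound 4.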

Compound 4, intrinsic activity: the largest response reached, as a fraction of the reference agonist's: 0.6
Compound 4: the middle estimate sits 0.40 below what was measured; measured number above the stated range.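

In this assay thiophen-2-yl gives a number at least 0.30 higher from compound 1 to compound 4 (beyond the scatter) and, set against 2-methylphenyl, gives a number at least 0.30 higher from compound 3 to compound 4 (beyond the scatter) so the group at this aromatic carbon can carry the maximal response clear of the limit. The two methylphenyl isomers gave no such sign. Compound 4 is the only one with a readable value, the rest sharing one limit: the limit of < 0.3 in this assay, at which 3 of the 4 values shown sit.

Going by these compounds, whether the step follows the sulfur or the five-membered ring stays open, and a furan-2-yl group at this carbon would separate the two. On these data alone, how far the response can rise also stays open, for instance with a chlorine or methyl on the thiophene ring.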